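The source may hold more compounds than are shown below. What is called first, only, known or untested is meant among the compounds shown, and "the series" means these compounds.

In an ADME assay on MRC5 cells (Homo sapiens) for antiproliferative activity, read by MTT assay (on this read-out lower numbers stand for stronger inhibition and higher numbers for weaker inhibition), compound 1 (`C/C(=N\NC(=O)c1ccc(O)cc1)c1cnccn1`) gives > 80000 nM and this is only a limit of the assay, not a number. Compound 2 (`C/C(=N\NC(=O)c1cccs1)c1cnccn1`) gives 5540 nM on the same read-out. Compound 3 (`C/C(=N\NC(=O)c1ccc([N+](=O)[O-])cc1)c1cnccn1`) gives 2870 nM on that read-out too. Compound 4 (`C/C(=N\NC(=O)c1ccc(Br)cc1)c1cnccn1`) differs from compound 1 in one place (bromo in place of hydroxy on an aromatic carbon). For the measured compounds named here, one measured step bears on this change, an at least 27-fold lower number from compound 1 to compound 3 (1.44 log units; beyond the scatter) and there the same hydroxy leaves, with nitro entering. With that single step as the guide, the expected change is an at least 20-fold lower number from compound 1 to compound 4 (1.30 log units; beyond the scatter) and it should be a large one toward lower numbers. For compound 4 in this assay the estimated value is 4000 nM within an expected range (1200 nM to 14000 nM).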

Compound 4, half-maximal inhibitory concentration: 2940 nM
Compound 4: the middle estimate sits 1.4-fold (0.13 log units) above what was measured; the range from low to high includes it.
By their numbers in this assay, from the lowest: compounds 3, 4 and 2 (each within the scatter of the next). At a limit, above all of these: compound 1.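

In this assay, bromo in place of hydroxy at this position gives an at least 27-fold lower number from compound 1 to compound 4 (1.43 log units; beyond the scatter) and so extends to a second group the large shift seen so far only with nitro. With a 1.0-fold higher number from compound 3 to compound 4 (0.01 log units; within the scatter) nitro and bromo cannot be told apart on this read-out. The size of the step from the hydroxy compound is only a bound, since compound 1 stands at a limit: the limit of > 80000 nM in this assay, at which 1 of the 4 values shown sits.

Still open, from the compounds shown here alone, is whether the shift comes from losing hydroxy or depends on the group that enters. An amine, a carboxylic acid or plain hydrogen in this place would separate those two readings.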